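Isopropyl to hydrogen on two related cores

A few compounds are considered here, and "the series" means these few. Any claim that something is new, unique, unknown or untested is made for them only; others in the source may bear on it.

Measured compounds:
compound 1, `C=C1[C@H](OC(C)=O)C[C@H](OC(C)=O)[C@@]2(C)[C@@H](OC(C)=O)C[C@@H](OC(C)=O)[C@]3(CO3)[C@@H]2[C@H](OC(C)=O)[C@]2(O)[C@@H](C)C(=O)O[C@H]2[C@H]1Cl`, giving 20500 nM
compound 2, `C=C1[C@H](OC(C)=O)C[C@H](OC(C)=O)[C@@]2(C)[C@@H](OC(C)=O)C[C@@H](OC(=O)CC(C)C)[C@]3(CO3)[C@@H]2[C@H](OC(C)=O)[C@]2(O)[C@@H](C)C(=O)O[C@H]2[C@H]1Cl`, giving 18000 nM
compound 3, `C=C1[C@H]2O[C@]3([C@@H](C)C(=O)O[C@H]3[C@H]1Cl)[C@@H](OC(C)=O)[C@H]1[C@@]3(CO3)[C@H](OC(=O)CC(C)C)C[C@H](OC(C)=O)[C@]1(C)[C@@H](OC(C)=O)[C@H]2OC(C)=O`, with only a limit, < 300 nM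

In a functional assay on MG-63 cells (Homo sapiens) for cytotoxicity, read by MTT assay (on this read-out higher numbers stand for weaker inhibition and lower numbers for stronger inhibition), compound 2 gives 18000 nM and compound 1 gives 20500 nM. The two differ by hydrogen in place of isopropyl on a saturated chain carbon bound to a carbonyl carbon, and the step is a 1.1-fold higher number from compound 2 to compound 1 (0.06 log units; within the scatter). Compound 3 rests on a different core; the difference between the two cores is not broken down here. In this assay compound 3 reaches only a limit, < 300 nM, which is the limit of < 300 nM in this assay, at which 1 of the 3 values shown sits.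

Compound 4, `C=C1[C@H]2O[C@]3([C@@H](C)C(=O)O[C@H]3[C@H]1Cl)[C@@H](OC(C)=O)[C@H]1[C@@]3(CO3)[C@H](OC(C)=O)C[C@H](OC(C)=O)[C@]1(C)[C@@H](OC(C)=O)[C@H]2OC(C)=O`, is not yet measured. It differs from compound 3 by hydrogen in place of isopropyl on a saturated chain carbon bound to a carbonyl carbon, the same change as from compound 2 to compound 1, made at the same place. The expected step is a step that the limit leaves unreadable from compound 3 to compound 4, resting on the measured step of a 1.1-fold higher number from compound 2 to compound 1 (0.06 log units; within the scatter), which lay within the scatter. Compound 4 is therefore estimated at 250 nM, with a range from 50 nM to 800 nM, and it may well again come back only as a limit in this assay.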

Compound 4, half-maximal inhibitory concentration: > 45700 nM
Compound 4: a limit, no number; the forecaster's own chance of this, stated with the estimate: 60%; at least 180-fold (2.26 log units) between middle value and limit.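

In this assay, replacing isopropyl with hydrogen on the core of compound 3 gives an at least 150-fold higher number from compound 3 to compound 4 (2.18 log units; beyond the scatter), a large loss in the direction of weaker inhibition. The same change on the other core gives a very different result, so in this series it did not carry from one core to the other: the same change on two cores in this assay, a 1.1-fold higher number (0.06 log units; within the scatter) from compound 2 to compound 1 and an at least 150-fold higher number (2.18 log units; beyond the scatter) from compound 3 to compound 4, at least 130-fold (2.12 log units) apart, beyond the scatter of two such steps. Within the data shown here, this shows that the small step on one core gave no guide to the step on the other, but it rests on a single pair per core and does not give the true size of the larger step, as compound 3 and compound 4 are each reported only as limits; nor does it show which feature of the cores separates the two results.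

As far as these compounds go, it remains open how much of the larger step belongs to the isopropyl group itself and how much to the length of the chain that carries it. A longer chain, an amine or a carboxylic acid in that place could show whether the sharp dependence on the core extends beyond these two pairs.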